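Aromatic Methyl in Two Ring-Size Variants of the Core

The source may hold more compounds than are shown below. What is called first, only, known or untested is meant among the compounds shown, and "the series" means these compounds.

Compound 1 `N/C(=N\NC(=S)N1CCCCCC1)c1ccccn1` gives 25.3% in a functional assay on MCF7 cells (Homo sapiens) for cytotoxicity, read by MTT assay, with a stated time of 72 h, tested at 1 uM; a lower number here means less inhibition of growth, a higher number more inhibition of growth at the concentration tested. Compound 3 `Cc1cccc(/C(N)=N/NC(=S)N2CCCCCC2)n1` carries methyl in place of hydrogen on an aromatic carbon and gives 6.3% in this assay, the step being a number 19 percentage points lower from compound 1 to compound 3 (beyond the scatter). Compound 2 `N/C(=N\NC(=S)N1CCCCC1)c1ccccn1` gives 15.4% in this assay; the difference between its core and the core of compound 1 is not broken down here. Compound 4 `Cc1ccnc(/C(N)=N/NC(=S)N2CCCCC2)c1` is not yet measured and differs from compound 2 by methyl in place of hydrogen on an aromatic carbon. This is the same kind of change as from compound 1 to compound 3, but not the same: there the methyl sits next to the ring nitrogen, here it sits opposite the ring nitrogen, in both cases meta to a large group. Resting on the step of a number 19 percentage points lower from compound 1 to compound 3 (beyond the scatter), a smaller downward step is expected for compound 4, a number 7.4 percentage points lower from compound 2 to compound 4 (within the scatter). Compound 4 is estimated at 8% in this assay, with a range from 0% to 22%.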

Compound 4, percent growth inhibition at one concentration: 21.2%
The estimate for compound 4 lay 13.2 percentage points below the measured number; low and high end bracket the measured number.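

In this assay the methyl in place of hydrogen on an aromatic carbon does not carry over as one fixed step from one core to the other: the same change on two cores in this assay, a number 19 percentage points lower (beyond the scatter) from compound 1 to compound 3 and a number 5.8 percentage points higher (within the scatter) from compound 2 to compound 4, 24.8 percentage points apart, beyond the scatter of two such steps. On the second core the step is a number 5.8 percentage points higher from compound 2 to compound 4 (within the scatter) and gives no sign of a change, so the drop seen on the core of compound 1 cannot be assumed for related compounds. The two pairs differ both in the core and in where the methyl sits, opposite the ring nitrogen in compound 4 and elsewhere in compound 3, so the compounds shown do not separate these two differences.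

The compounds shown leave open how methyl at one and the same place behaves on both cores. They also leave open how an ethyl, a methoxy or a chlorine at these places would read.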